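The source may report more compounds than this note shows. Statements on the series, on what has been measured and on what is new or still open speak of the compounds shown alone.

Among the measured compounds shown here, compound 1 `O=C(Nc1ccnnc1)c1cc(N2C[C@H]3COC[C@H]3C2)ccc1OCc1ccccc1` is one of three compounds measured in a physicochemical assay for lipophilicity, at pH 7.4; on this read-out lower numbers stand for lower lipophilicity and higher numbers for higher lipophilicity. In this assay compound 1 gives 4.5, the second highest of the three numbers. Compound 2 `O=C(Nc1ccnnc1)c1cc(N2CCCCC2)ccc1OCc1ccccc1` gives 6.3, and the step between them is a number 1.80 log units higher from compound 1 to compound 2 (beyond the scatter). Compound 3 `O=C(Nc1ccnnc1)c1cc(N2CCC(O)CC2)ccc1OCc1ccccc1` gives 3.2, with a number 1.30 log units lower from compound 1 to compound 3 (beyond the scatter); between compound 2 and compound 3 the step is a number 3.10 log units lower from compound 2 to compound 3 (beyond the scatter). Compound 4 `N#CC1CCN(c2ccc(OCc3ccccc3)c(C(=O)Nc3ccnnc3)c2)CC1` has not yet been measured. The change from compound 1 is a group of 8 heavy atoms (6 carbon, 2 nitrogen; one six-membered non-aromatic ring with 1 hetero atom) in place of a group of 8 heavy atoms (6 carbon, 1 nitrogen, 1 oxygen; 2 five-membered non-aromatic rings with 1 hetero atom each), on an aromatic carbon. For the measured compounds named here, two measured steps bear on it: the ring swap seen in a number 1.80 log units higher from compound 1 to compound 2 (beyond the scatter) and the substituent step seen in a number 3.10 log units lower from compound 2 to compound 3 (beyond the scatter). Compound 4 carries the ring of compound 2 with a nitrile added, as compound 3 carries that ring with a hydroxy added, so its number is expected to fall between those of compound 2 and compound 3, and the step of a number 0.50 log units higher from compound 1 to compound 4 (beyond the scatter) is expected to be upward and modest. The estimate for compound 4 is 5, between 4.2 and 5.8.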

Compound 4, distribution coefficient: 4.5
The estimate for compound 4 lay 0.50 log units above the measured number; the range from low to high includes it.
By their numbers in this assay, from the lowest: compound 3; then compounds 1 and 4 (each within the scatter of the next); then compound 2.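

In this assay, the 4-cyanopiperidin-1-yl group of compound 4 and the two-ring group of compound 1 cannot be told apart (no change at the digits printed from compound 1 to compound 4 (within the scatter)), so at this position, para to the benzyloxy group, two quite different ring shapes can give the same reading. Placing a nitrile on the six-membered ring of compound 2 is a large change in its own right (a number 1.80 log units lower from compound 2 to compound 4 (beyond the scatter)). Nitrile and hydroxy on that same ring carbon also stay far from each other (a number 1.30 log units higher from compound 3 to compound 4 (beyond the scatter)), so the reading depends strongly on which substituent sits there.

Nothing given here explains the size of any of these steps. As far as these compounds go, it remains open where a primary amine or a carboxylic acid on that ring carbon would fall relative to compound 2, compound 3 and compound 4.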